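This account rests on a few compounds, and the source may have more. Where it says the series, first, only, none or still open, it means among the compounds named here.

Measured in an ADME assay (liver) for metabolic stability, with Liver microsome (Rattus norvegicus) as the target, using microsomes and NADPH, with a stated time of 30 min, tested at 1 uM; a higher number here means faster removal of the compound, a lower number slower removal:
- Compound 1 `Nc1ccc(S(=O)(=O)N2CCN(c3ncc(C(O)(C(F)(F)F)C(F)(F)F)cc3-c3cccc(F)c3)CC2)cn1`: 52 mL.min-1.g-1
- Compound 2 `Nc1ccc(S(=O)(=O)N2CCN(c3ncc(C(O)(C(F)(F)F)C(F)(F)F)cc3-c3ccc4ocnc4c3)CC2)cn1`: 120 mL.min-1.g-1

Compound 2 holds the higher of the two numbers, 120 mL.min-1.g-1. Compound 3 `Nc1ccc(S(=O)(=O)N2CCN(c3ncc(C(O)(C(F)(F)F)C(F)(F)F)cc3-c3ccc4c(c3)CC(=O)N4)CC2)cn1` is the next to be read, and it differs from compound 2 as follows: a group of 10 heavy atoms (8 carbon, 1 nitrogen, 1 oxygen; one five-membered non-aromatic ring with 1 hetero atom, one six-membered aromatic ring of carbon only) in place of a group of 9 heavy atoms (7 carbon, 1 nitrogen, 1 oxygen; one five-membered aromatic ring with 2 hetero atoms, one six-membered aromatic ring of carbon only), on an aromatic carbon. The six-membered aromatic ring of carbon only stays, while the five-membered ring becomes non-aromatic.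

Within the data shown here, only one measured step bears on this place: a 2.3-fold higher number from compound 1 to compound 2 (0.36 log units; beyond the scatter). It is modest, and it involves 3-fluorophenyl rather than the group entering here, so it gives only a rough scale. Among the measured compounds shown here, no measured compound carries that group. No step beyond the scatter is therefore expected, with a slight lean towards a lower number. The estimated step is a 1.4-fold lower number from compound 2 to compound 3 (0.15 log units; within the scatter). Compound 3 is expected at 85 mL.min-1.g-1, with an estimated range of 38 mL.min-1.g-1 to 180 mL.min-1.g-1.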

Compound 3, intrinsic clearance in microsomes: 119 mL.min-1.g-1
Compound 3: middle estimate off by 1.4-fold (0.15 log units), on the low side, and the stated range covers the measured number.
By their numbers in this assay, from the lowest: compound 1; then compounds 3 and 2 (each within the scatter of the next).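

In this assay the exchange of 1,3-benzoxazol-5-yl for the entering group gives a 1.0-fold lower number from compound 2 to compound 3 (0.00 log units; within the scatter), so at this place, ortho to a large group, the two fused groups cannot be told apart, even though the five-membered ring is no longer aromatic and the entering group carries a hydrogen-bond donor. Measured against 3-fluorophenyl, the entering group gives a 2.3-fold higher number from compound 1 to compound 3 (0.36 log units; beyond the scatter), a step of the same printed size as a 2.3-fold higher number from compound 1 to compound 2 (0.36 log units; beyond the scatter), which shows that this rise is not confined to 1,3-benzoxazol-5-yl. Among these three compounds, both fused groups stand apart from 3-fluorophenyl.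

Still open, going by these compounds, is where a phenyl group bearing a carboxylic acid or a morpholine at this place would fall relative to compound 1 and compound 3. Nothing available accounts for the values of any of these three compounds.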